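The source may report more compounds than this note shows. Statements on the series, on what has been measured and on what is new or still open speak of the compounds shown alone.

Compound 1, `Cc1noc(C)c1-c1ccc2c(c1)C(c1ccccc1)N(Cc1nnc(-c3ccccc3)s1)C(=O)N2C`, gives 35.2% in a functional assay on HepG2 cells (Homo sapiens) for inhibition, read by MTT assay, with a stated time of 48 h, tested at 2 uM; a lower number here means less inhibition, a higher number more inhibition at the concentration tested (going by the name of the read-out).
Compound 2, `Cc1noc(C)c1-c1ccc2c(c1)C(c1ccccc1)N(Cc1nc(-c3ccccc3)cs1)C(=O)N2C`, gives 44.5% in this assay.

Compound 2 stands highest of the two numbers, but its nearest neighbour compound 1 lies only a number 9.3 percentage points higher from compound 1 to compound 2 (within the scatter), which is within the scatter, so the two cannot be told apart. Compound 3, `Cc1noc(C)c1-c1ccc2c(c1)C(c1ccccc1)N(Cc1nnc(-c3ccc(F)cc3)o1)C(=O)N2C`, has not been measured. It differs from compound 2 in one place: 5-(4-fluorophenyl)-1,3,4-oxadiazol-2-yl in place of 4-phenyl-1,3-thiazol-2-yl on a saturated chain carbon bound to an amide-type nitrogen in a ring. For the measured compounds named here, the only measured step bears on it loosely: swapping one five-membered aromatic ring with two hetero atoms for one with three hetero atoms between compound 1 and compound 2 gave a number 9.3 percentage points higher from compound 1 to compound 2 (within the scatter), within the scatter. Compound 3 again carries a five-membered ring with three hetero atoms, so no step beyond the scatter is expected in this assay; the estimated change is a number 6.5 percentage points lower from compound 2 to compound 3 (within the scatter). Compound 3 is therefore expected to give about 38%, between 22% and 54%.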

Compound 3, a percentage reported as inhibition, at one concentration (the size of the read-out at that concentration, not a potency): 52.8%
Compound 3: middle estimate off by 14.8 percentage points, on the low side; the range from low to high includes it.
By their numbers in this assay, from the lowest: compounds 1, 2 and 3 (each within the scatter of the next, the first and the last beyond it).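

At this position, on a saturated chain carbon bound to an amide-type nitrogen in a ring, 5-(4-fluorophenyl)-1,3,4-oxadiazol-2-yl can stand in for 4-phenyl-1,3-thiazol-2-yl without a clear change in this assay (a number 8.3 percentage points higher from compound 2 to compound 3 (within the scatter)). Set against 5-phenyl-1,3,4-thiadiazol-2-yl, the same group gives the first step at this position that clears the usual scatter, though only a modest one (a number 17.6 percentage points higher from compound 1 to compound 3 (beyond the scatter)). Nothing measured on these groups explains that step.

That step changes both the five-membered ring and the fluorine on the phenyl ring, so a plain 5-phenyl-1,3,4-oxadiazol-2-yl group would be needed to tell their shares apart. Also open, as far as these compounds go, is how this position responds to a group with no aromatic ring at all, such as an amine or a carboxylic acid.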